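Chloro added to the trifluoromethyl compound

A few compounds are considered here, and "the series" means these few. Any claim that something is new, unique, unknown or untested is made for them only; others in the source may bear on it.

Going by the values given here, in a functional assay on the whole organism for inhibition, with Scenedesmus acutus as the target, with a stated time of 20 min (on this read-out higher numbers stand for weaker inhibition and lower numbers for stronger inhibition), compound 1 `O=c1c2c(sn1-c1ccc(C(F)(F)F)cc1)CCCC2` gives 74100 nM, the highest of the three numbers so far, against compound 2 `O=c1c2c(sn1-c1ccc(Cl)cc1)CCCC2` at 20400 nM and compound 3 `O=c1c2c(sn1-c1ccc([N+](=O)[O-])cc1)CCCC2` at 23400 nM. Compound 4 `O=c1c2c(sn1-c1ccc(C(F)(F)F)cc1Cl)CCCC2` keeps the trifluoromethyl group of compound 1 and differs by chloro in place of hydrogen on an aromatic carbon, ortho to a large group and meta to a trifluoromethyl group. Among the compounds with values here, no measured step adds a group at this place. The closest evidence comes from replacing the trifluoromethyl group itself, which gave a 3.6-fold lower number from compound 1 to compound 2 (0.56 log units; beyond the scatter) with chloro and a 3.2-fold lower number from compound 1 to compound 3 (0.50 log units; beyond the scatter) with nitro. This indirect evidence points to a modest move towards stronger inhibition. The expected step is a 1.9-fold lower number from compound 1 to compound 4 (0.27 log units; within the scatter). Compound 4 is estimated at 40000 nM, with an expected range of 15000 nM to 100000 nM.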

Compound 4, half-maximal inhibitory concentration: 15800 nM
For compound 4 the middle estimate is 2.5-fold (0.40 log units) above the measured one; low and high end bracket the measured number.
By their numbers in this assay, from the lowest: compounds 4, 2 and 3 (each within the scatter of the next); then compound 1.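

Adding chloro in place of hydrogen on this aromatic carbon, ortho to a large group and meta to a trifluoromethyl group, gives stronger inhibition in this assay while the trifluoromethyl group stays: a 4.7-fold lower number from compound 1 to compound 4 (0.67 log units; beyond the scatter). Going by these compounds alone, the earlier steps changed only the trifluoromethyl group itself, so this is the first sign that this position also affects the read-out. No measurement on hand accounts for the step.

Open, on these data alone, is whether a methoxy group or an amine at this position would move the number the same way. Also open, as far as these compounds go, is whether chloro here has a similar effect in compound 2 or compound 3.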